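Cyclohexyl in place of butyl: compound 3 to compound 4

This account rests on a few compounds, and the source may have more. Where it says the series, first, only, none or still open, it means among the compounds named here.

In a functional assay, read by fluorescence and spectrophotometry, with a stated time of 1 h (on this read-out higher numbers stand for an effect only at larger amounts of compound and lower numbers for an effect already at smaller amounts), compound 3 (`CCCCCCCS(=O)(=O)/C=C/c1ccc(O)c(O)c1`) gives 7100 nM and stands within the scatter of both other measured compounds: compound 1 (`O=S(=O)(/C=C/c1ccc(O)c(O)c1)CCC1CCCC1`) gives 6800 nM and compound 2 (`CCCCCCCCCCCS(=O)(=O)/C=C/c1ccc(O)c(O)c1`) gives 11400 nM in the same read-out. Compound 4 (`O=S(=O)(/C=C/c1ccc(O)c(O)c1)CCCC1CCCCC1`) carries cyclohexyl in place of butyl on a saturated chain carbon, three bonds along the chain from a sulfonyl sulfur. Among the compounds with values here, two measured steps bear on this change, pentyl in place of cyclopentyl (a 1.0-fold higher number from compound 1 to compound 3 (0.02 log units; within the scatter)) and hydrogen in place of butyl (a 1.6-fold lower number from compound 2 to compound 3 (0.21 log units; within the scatter)), and both stay within the scatter. No step beyond the scatter is therefore expected in this assay for this change. The estimated step is small (a 1.1-fold higher number from compound 3 to compound 4 (0.05 log units; within the scatter)). For compound 4 the expected value is 8000 nM with an estimated range of 4000 nM to 15000 nM overall.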

Compound 4, half-maximal effective concentration: 7900 nM
Estimate against measurement, compound 4: 1.0-fold (0.01 log units) above; measured number inside the range.
By their numbers in this assay, from the lowest: compounds 1, 3, 4 and 2 (each within the scatter of the next).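

In this assay, cyclohexyl in place of butyl, three bonds along the chain from a sulfonyl sulfur, puts a six-membered non-aromatic ring at this place and stays within the scatter (a 1.1-fold higher number from compound 3 to compound 4 (0.05 log units; within the scatter)). The same holds for cyclohexyl in place of octyl (a 1.4-fold lower number from compound 2 to compound 4 (0.16 log units; within the scatter)) and for cyclohexylmethyl in place of cyclopentyl (a 1.2-fold higher number from compound 1 to compound 4 (0.07 log units; within the scatter)). This read-out therefore does not separate the cyclohexyl chain of compound 4 from the open chains of compound 2 and compound 3 or from the cyclopentyl chain of compound 1.

On these data alone, whether an amine or a carboxylic acid on this chain would give a step beyond the scatter remains open. No supporting data bear on this result.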